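Swapping the side chain on the amino acid carbon

The compounds below may be only part of what the source reports. "The series", "measured", "known", "first", "only" and "open" are said of these compounds alone.

Three compounds share one core and differ only in the group on a saturated chain carbon bound to an amide-type nitrogen and a carbonyl carbon. In a functional assay on the whole organism (Tail, strain ICR) with Mus musculus as the target, in the tail flick test, with a stated time of 30 min, at a dose of 25 umol/kg by the oral route (on this read-out lower numbers stand for a weaker effect and higher numbers for a stronger effect at the one dose given), compound 1 `O=C(CN(c1ncnc2c1ncn2C1CCCCO1)C1CC1)N[C@@H](CCC(=O)OCc1ccccc1)C(=O)OCc1ccccc1` gives 32.6%, compound 2 `CC[C@H](C)[C@H](NC(=O)CN(c1ncnc2c1ncn2C1CCCCO1)C1CC1)C(=O)OCc1ccccc1` gives 25.6%, and compound 3 `C[C@@H](O)[C@H](NC(=O)CN(c1ncnc2c1ncn2C1CCCCO1)C1CC1)C(=O)OCc1ccccc1` gives 23.6%. Compound 3 stands at the lowest of the three numbers, yet the gaps are small: a number 9 percentage points lower from compound 1 to compound 3 (within the scatter) and a number 2 percentage points lower from compound 2 to compound 3 (within the scatter). Compound 4 `NC(=O)C[C@H](NC(=O)CN(c1ncnc2c1ncn2C1CCCCO1)C1CC1)C(=O)OCc1ccccc1` differs from compound 3 by carbamoylmethyl in place of 1-hydroxyethyl on a saturated chain carbon bound to an amide-type nitrogen and a carbonyl carbon. Among the compounds with values here, no measured step introduces carbamoylmethyl at this place; the two steps ending at compound 3 bear on it only as swaps at the same place, and both stayed within the scatter. A step of a number 1.4 percentage points higher from compound 3 to compound 4 (within the scatter) is therefore expected, nothing beyond the scatter. Compound 4 is estimated at 25%, within 12% to 38%.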

Compound 4, a percentage reported as activity, at one dose (the size of the read-out at that dose, not a potency): 34.5%
Compound 4: middle estimate off by 9.5 percentage points, on the low side; the measured number falls inside the stated range.
By their numbers in this assay, from the lowest: compounds 3, 2, 1 and 4 (each within the scatter of the next, the first and the last beyond it).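

Carbamoylmethyl at this place gives the first step beyond the scatter in this series (a number 10.9 percentage points higher from compound 3 to compound 4 (beyond the scatter)), so the side chain can shift this assay, if only modestly. The other two steps stay within the scatter (a number 8.9 percentage points higher from compound 2 to compound 4 (within the scatter)) and (a number 1.9 percentage points higher from compound 1 to compound 4 (within the scatter)), so only the swap for 1-hydroxyethyl separates from the scatter. Nothing available explains this step.

Going by these compounds, what a carboxylic acid or an amine on a longer chain would do at this place remains open.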